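The source may report more compounds than this note shows. Statements on the series, on what has been measured and on what is new or still open speak of the compounds shown alone.

Among the compounds with values here, compound 1 `CC(C)C[C@@H](NC(=S)Nc1cc(C(F)(F)F)cc(C(F)(F)F)c1)c1nc2ccccc2[nH]1` gives 91000 nM in a functional assay on MCF7 cells (Homo sapiens) for cytotoxicity, read by MTT assay (on this read-out lower numbers stand for stronger inhibition and higher numbers for weaker inhibition), the highest of the three numbers known so far: compound 3 `CC(C)C[C@@H](NC(=S)NCc1ccccc1)c1nc2ccccc2[nH]1` gives 18200 nM and compound 2 `C[C@@H](NC(=S)NCc1ccccc1)c1nc2ccccc2[nH]1` gives 14300 nM, each lower than compound 1 by more than the scatter. Compound 4 `CC(C)[C@@H](NC(=S)Nc1cc(C(F)(F)F)cc(C(F)(F)F)c1)c1nc2ccccc2[nH]1` differs from compound 1 only at the side chain: isopropyl in place of isobutyl on a saturated chain carbon bound to an amide-type nitrogen and an aromatic carbon. Within the data shown here, the one measured step that touches this chain is a 1.3-fold higher number from compound 2 to compound 3 (0.10 log units; within the scatter), in which adding bulk at the same place left the read-out essentially unchanged. Because compound 1 gave 91000 nM with the larger chain, compound 4 is expected to land close to that number, with a 1.1-fold lower number from compound 1 to compound 4 (0.03 log units; within the scatter) not beyond the scatter. Compound 4 is therefore estimated at 85000 nM, in a range from 40000 nM to 180000 nM.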

Compound 4, half-maximal inhibitory concentration: 16400 nM
Compound 4: the middle estimate sits 5.2-fold (0.71 log units) above what was measured; measured number below the stated range.
By their numbers in this assay, from the lowest: compounds 2, 4 and 3 (each within the scatter of the next); then compound 1.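

In this assay the exchange of isobutyl for isopropyl on this saturated chain carbon gives a 5.5-fold lower number from compound 1 to compound 4 (0.74 log units; beyond the scatter) and so lies beyond the scatter, whereas the earlier step on this chain, a 1.3-fold higher number from compound 2 to compound 3 (0.10 log units; within the scatter), did not. The read-out at this position can therefore respond to a small change in the chain, at least in the setting of compound 1. Nothing on hand accounts for this difference. As far as these compounds go, how a longer chain or a hydroxymethyl group would read at this carbon remains open, as does whether isopropyl would give a similar step in the setting of compound 3.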